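The compounds below may be only part of what the source reports. "The series", "measured", "known", "first", "only" and "open" are said of these compounds alone.

Compound 1 `CC#C[C@@H](CC(=O)O)c1ccc(OCc2cccc(-c3ccc(Cl)cc3C)c2)cc1` gives 36 nM in an assay on CHO cells for agonist activity at Free fatty acid receptor 1 (Homo sapiens), read by calcium flux; a lower number here means that less compound is needed, a higher number that more compound is needed for the effect.
Compound 2 `Cc1cc(Cl)ccc1-c1cccc(COc2ccc([C@H](CC(=O)O)c3ncnn3C)cc2)c1` gives 33 nM in this assay.
Compound 3 `Cc1nc(-c2ccc(C(F)(F)F)cc2)sc1COc1ccc([C@H](CC(=O)O)c2nccn2C)cc1` gives 73 nM in this assay.

Compound 3 stands highest of the three, beyond the scatter from both compound 1 and compound 2. Compound 4 `Cc1nc(-c2ccc(C(F)(F)F)cc2)sc1COc1ccc([C@H](CC(=O)O)c2ncco2)cc1` keeps the core of compound 3 and differs in one place: 1,3-oxazol-2-yl in place of 1-methyl-1H-imidazol-2-yl on a saturated chain carbon bound to an aromatic carbon and a saturated chain carbon. Among the compounds with values here, no measured step swaps one five-membered aromatic ring for another at this carbon; the only recorded step at this place, a 1.1-fold lower number from compound 1 to compound 2 (0.04 log units; within the scatter), replaced a chain by such a ring and stayed within the scatter. That suggests this position tolerates change, so no step beyond the scatter is expected in this assay, though a small rise remains possible. Compound 4 is therefore estimated at 90 nM, with a range of 40 nM to 220 nM, meaning a step of a 1.2-fold higher number from compound 3 to compound 4 (0.09 log units; within the scatter) is expected.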

Compound 4, half-maximal effective concentration: 69 nM
Compound 4: middle estimate off by 1.3-fold (0.12 log units), on the high side; low and high end bracket the measured number.
By their numbers in this assay, from the lowest: compounds 2, 1, 4 and 3 (each within the scatter of the next, the first and the last beyond it).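

The step of a 1.1-fold lower number from compound 3 to compound 4 (0.02 log units; within the scatter) stays within the scatter in this assay, so one five-membered aromatic ring can stand in for another on this saturated chain carbon. The earlier step had only replaced a chain with such a ring, on a different core; this tolerance now also appears on the core of compound 3, where 1,3-oxazol-2-yl matches 1-methyl-1H-imidazol-2-yl. No measurement here explains why the two rings give such similar numbers.

Still open, from the compounds shown here alone, is whether a phenyl ring would be tolerated on this carbon. An amine there is equally untested among the compounds shown.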